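The source may hold more compounds than are shown below. What is called first, only, known or untested is meant among the compounds shown, and "the series" means these compounds.

The measured compounds: compound 1 `O=C(Nc1nccs1)c1cc(=O)c2ccccc2o1`, compound 2 `O=C(Nc1nc[nH]n1)c1cc(=O)c2ccccc2o1`, compound 3 `O=C(Nc1nnn[nH]1)c1cc(=O)c2ccccc2o1`.

In a functional assay on cells (Mast cell, Rattus norvegicus) for inhibition, with a stated time of 15 min (on this read-out lower numbers stand for an effect already at smaller amounts and higher numbers for an effect only at larger amounts of compound), compound 1 gives only a limit of the assay, > 18 ug/mL. In this assay compound 2 gives 5 ug/mL and compound 3 gives 0.08 ug/mL. Compound 3 therefore gives the lowest number shown; its nearest neighbour is compound 2, and the step of a 63-fold lower number from compound 2 to compound 3 (1.80 log units; beyond the scatter) is large. Compound 4 `CN(C(=O)c1cc(=O)c2ccccc2o1)c1nnn[nH]1` differs from compound 3 in one place: methyl in place of hydrogen on an amide-type nitrogen. For the measured compounds named here, none of the measured steps touches the hydrogen on this nitrogen; each exchanges the ring attached to it, as in an at least 220-fold lower number from compound 1 to compound 3 (2.35 log units; beyond the scatter) and an at least 3.6-fold lower number from compound 1 to compound 2 (0.55 log units; beyond the scatter). So no measured step bears directly on this change. With that gap, a higher number for compound 4 is expected, with wide uncertainty. The expected step is a 13-fold higher number from compound 3 to compound 4 (1.10 log units; beyond the scatter). Compound 4 is estimated at 1 ug/mL, within a range from 0.1 ug/mL to 20 ug/mL.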

Compound 4, concentration for half-maximal effect: > 18 ug/mL
Compound 4: a limit, no number; the forecaster's own chance of this, stated with the estimate: 25%; middle value at least 18-fold (1.25 log units) away from the limit.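

The earlier steps shown here exchanged only the ring on the amide-type nitrogen, while this one keeps the 1H-tetrazol-5-yl ring and changes the nitrogen itself. Methyl in place of hydrogen there alone gives an at least 220-fold higher number from compound 3 to compound 4 (2.35 log units; beyond the scatter) in this assay, so this single hydrogen position matters on this read-out as much as the ring exchanges do. The true size of the step cannot be read, as compound 4 gives only a limit: the limit of > 18 ug/mL in this assay, at which 2 of the 4 values shown sit.

As far as these compounds go, what a longer chain or an amine on this nitrogen would do stays open. So does whether methyl would have a similar effect with the 1H-1,2,4-triazol-3-yl ring of compound 2.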